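A few compounds are considered here, and "the series" means these few. Any claim that something is new, unique, unknown or untested is made for them only; others in the source may bear on it.

Measured so far:
- compound 1, `Nc1nc(O)c2c(n1)n(C1OC(CO)[C@@H](O)[C@H]1O)c(=O)n2Cc1ccc(Cl)cc1`: 15%
- compound 2, `C=CCn1c(=O)n(C2OC(CO[Si](c3ccccc3)(c3ccccc3)C(C)(C)C)[C@@H](O)[C@H]2O)c2nc(N)nc(O)c21`: 33%
- compound 3, `C=CCn1c(=O)n(CCCC)c2nc(N)nc(O)c21`: 77%

All three compounds were tested in a functional assay on the whole organism (B cells) with Mus musculus as the target; on this read-out higher numbers stand for larger maximal responses and lower numbers for smaller maximal responses. Compound 1 gives the lowest of the three numbers with 15%. The nearest number belongs to compound 2 with 33%, and the gap between the two lies beyond the usual scatter. Compound 3 gives the highest number with 77%, far beyond the scatter from compound 1. No two of the measured compounds differ in only one place, so none of these gaps can be tied to a single structural change.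

The unmeasured compound 4, `Nc1nc(O)c2c(n1)n(C1OC(CO)[C@@H](O)[C@H]1O)c(=O)n2CCN1CCCCC1`, is derived from compound 1 by one change: (piperidin-1-yl)methyl in place of 4-chlorophenyl on a saturated chain carbon bound to an aromatic nitrogen. Since no single-step comparison among the measured compounds is available, the size of this step in this assay is uncertain. A moderate rise is expected, because compound 1 gives 15% and every other measured compound gives a larger maximal response. The step expected from compound 1 to compound 4 is a number 15 percentage points higher from compound 1 to compound 4 (beyond the scatter). For compound 4 the estimate in this assay is 30%, within a range from 10% to 60%.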

Compound 4, largest response reached (reported as maximal response), in percent of the reference or control that the assay uses: 0%
The estimate for compound 4 lay 30 percentage points above the measured number; the measured number lies below the stated range.
By their numbers in this assay, from the lowest: compound 4; then compound 1; then compound 2; then compound 3.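

Replacing 4-chlorophenyl with (piperidin-1-yl)methyl on a saturated chain carbon bound to an aromatic nitrogen gives, in this assay, a number 15 percentage points lower from compound 1 to compound 4 (beyond the scatter). Among the compounds shown here, this is the first reading of a single change here: the maximal response shifts when only this group differs and the rest of the structure stays the same, even though the leaving and entering groups have the same heavy-atom count. No measurement shown gives a reason for this step.

The change swaps several features at once, removing the chlorine and the aromatic ring while adding a ring nitrogen, and the compounds shown do not separate these features. A plain benzyl group or a 2-cyclohexylethyl group at this place would be the kind of comparison that could tell them apart.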